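The source may hold more compounds than are shown below. What is called first, only, known or untested is meant among the compounds shown, and "the series" means these compounds.

Compound 2, `COc1cc(N(Cc2nc3ccccc3[nH]2)S(=O)(=O)c2ccccc2)cc(OC)c1OC`, is the reference point of this account. In a functional assay on MCF7 cells (Homo sapiens) for inhibition, read by MTT assay, with a stated time of 48 h (on this read-out higher numbers stand for weaker inhibition and lower numbers for stronger inhibition), compound 2 gives 27300 nM, which is the lowest of the two numbers recorded in this assay. Its nearest companion is compound 3, `Cc1ccc(S(=O)(=O)N(Cc2nc3ccccc3[nH]2)c2ccccc2)cc1`, which in this assay gives 49700 nM; the gap between the two lies within the scatter of the method. Compound 1, `COc1ccc(CN(c2cc(OC)c(OC)c(OC)c2)S(=O)(=O)c2ccccc2)cc1`, gives in this assay only a limit, > 50000 nM. Taken together the three results show that (the limit of > 50000 nM in this assay, at which 1 of the 3 values shown sits). Within the data shown here, the single step that can be followed between measured compounds, an at least 1.8-fold lower number from compound 1 to compound 2 (0.26 log units; that floor lies within the scatter), runs against a limit and stays within the scatter.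

Compound 4 is `COc1cc(N(Cc2nc3ccccc3[nH]2)C(=O)c2ccc(F)cc2)cc(OC)c1OC`. It differs from compound 2 by (4-fluorophenyl)carbonyl in place of phenylsulfonyl on a nitrogen on an aromatic ring. Among the measured compounds shown here, none of the measured steps touches this part of the molecule: the one step recorded, from compound 1 to compound 2, exchanges the group on the saturated chain carbon, not the group on the sulfonamide nitrogen. For the measured compounds named here, there is therefore no measured step that bears on the change from compound 2 to compound 4, and no shift beyond the scatter is expected in this assay. The step of a 1.1-fold lower number from compound 2 to compound 4 (0.04 log units; within the scatter) is expected to be small. Compound 4 is expected to give 25000 nM, with a range from 8000 nM to 80000 nM.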

Compound 4, half-maximal inhibitory concentration: 45200 nM
Beside the measured number, compound 4's estimate is 1.8-fold (0.26 log units) below it; measured number inside the range.
By their numbers in this assay, from the lowest: compounds 2, 4 and 3 (each within the scatter of the next). At a limit, above all of these: compound 1.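

Until compound 4, every compound shown carried a sulfonyl group on this nitrogen, so the position had been seen with only one kind of link. In this assay, (4-fluorophenyl)carbonyl in place of phenylsulfonyl gives a 1.7-fold higher number from compound 2 to compound 4 (0.22 log units; within the scatter), so this exchange, which swaps the sulfonyl link for a carbonyl and adds a fluorine while keeping the same number of heavy atoms, yields no difference that the read-out can separate from the scatter, and a sulfonyl group is thus not needed on this nitrogen for a reading in this range. Compound 1 still stands as the only compound that gives a limit rather than a number: the limit of > 50000 nM in this assay, at which 1 of the 4 values shown sits.

The exchange changes the link and the fluorine together, so the compounds shown do not tell whether either change alone would matter, and a plain benzoyl group at this position would be needed to part the two. On these data alone, whether a different kind of group on this nitrogen, such as an acetyl, a methanesulfonyl or a benzyl group, could give a step beyond the scatter also stays open.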